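Replacing the cyano group of compound 3

The compounds below may be only part of what the source reports. "The series", "measured", "known", "first", "only" and "open" are said of these compounds alone.

Measured in a functional assay on U-373MG ATCC cells for cytotoxicity against U373 MG (Homo sapiens), read by colorimetric assay and MTT assay; on this read-out higher numbers stand for weaker inhibition and lower numbers for stronger inhibition:
- compound 1 `CCOC(=O)Cn1c(=O)c(-c2ccc(OC)cc2)cc2c(OC)cc(OC)cc21` gives 10000 nM
- compound 2 `COc1ccc(-c2cc3c(OC)cc(OC)cc3n(CC(=O)O)c2=O)cc1` gives 10000 nM
- compound 3 `COc1ccc(-c2cc3c(OC)cc(OC)cc3n(CCC#N)c2=O)cc1` gives 10000 nM

Compound 3 stands level with compound 1 and compound 2 at the digits shown. The next structure, compound 4 `CCN(CC)C(=O)CCn1c(=O)c(-c2ccc(OC)cc2)cc2c(OC)cc(OC)cc21`, carries diethylcarbamoyl in place of cyano on a saturated chain carbon, two bonds along the chain from an aromatic nitrogen. Three measured changes at this chain bear on it: no change at the digits printed from compound 1 to compound 2 (within the scatter), no change at the digits printed from compound 1 to compound 3 (within the scatter) and no change at the digits printed from compound 2 to compound 3 (within the scatter). None brought in diethylcarbamoyl, so the evidence is indirect, but no step beyond the scatter, in either direction, is expected in this assay. The expected step is no change at the digits printed from compound 3 to compound 4 (within the scatter). Compound 4 is estimated at 10000 nM, with an expected range of 4000 nM to 20000 nM.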

Compound 4, half-maximal inhibitory concentration: 10000 nM
The estimate for compound 4 equals the measured number at the digits printed; measured number inside the range.
By their numbers in this assay, from the lowest: compounds 1, 2, 3 and 4 (each within the scatter of the next).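

In this assay, putting diethylcarbamoyl with its 7 heavy atoms in place of the 2 of cyano gave no change at the digits printed from compound 3 to compound 4 (within the scatter) and so did not move the read-out. Set against the acid and the ester, the new chain likewise shows no change at the digits printed from compound 2 to compound 4 (within the scatter) and no change at the digits printed from compound 1 to compound 4 (within the scatter) here. Nothing measured here gives a reason for this flat result. Still open, going by these compounds, is whether an amine or a longer chain at this place on the shared core would produce any step beyond the scatter.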